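A few compounds are considered here, and "the series" means these few. Any claim that something is new, unique, unknown or untested is made for them only; others in the source may bear on it.

Three compounds that share one core and differ in the saturated chain on the amide carbonyl have been read in an ADME assay on Vero cells (Chlorocebus sabaeus) for cytotoxicity, read by reporter gene assay, with a stated time of 4 days; a lower number here means a stronger inhibitor, a higher number a weaker inhibitor. Compound 1 `CCCCCCCC(=O)NCC(C)(C)CC1=C(O)C(=O)c2ccccc2C1=O` gives 18400 nM, compound 2 `CCCCCCCCCC(=O)NCC(C)(C)CC1=C(O)C(=O)c2ccccc2C1=O` gives 15000 nM, and compound 3 `CCCCCCCCCCC(=O)NCC(C)(C)CC1=C(O)C(=O)c2ccccc2C1=O` gives 14900 nM. Compound 3 therefore stands within the scatter of both other compounds, and the three numbers form a single level rather than a ranking.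

Compound 4 `CCCCCCCCCCCC(=O)NCC(C)(C)CC1=C(O)C(=O)c2ccccc2C1=O` has not yet been measured. Its difference from compound 3 is methyl in place of hydrogen on a saturated chain carbon, ten or more bonds along the chain from a carbonyl carbon, which is methyl in place of hydrogen on a saturated chain carbon, ten or more bonds along the chain from a carbonyl carbon. Within the data shown here, the closest precedent is the same replacement nine bonds along the chain, a 1.0-fold lower number from compound 2 to compound 3 (0.00 log units; within the scatter). Two larger changes on the chain bear on it as well: a 1.2-fold lower number from compound 1 to compound 2 (0.09 log units; within the scatter) and a 1.2-fold lower number from compound 1 to compound 3 (0.09 log units; within the scatter). All three steps lie within the scatter, so no step beyond the scatter is expected in this assay, in either direction. The expected step is a 1.0-fold lower number from compound 3 to compound 4 (0.01 log units; within the scatter). For compound 4 the estimate is 14500 nM. The expected range for compound 4 runs from 9000 nM to 22000 nM.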

Compound 4, half-maximal inhibitory concentration: 13900 nM
Beside the measured number, compound 4's estimate is 1.0-fold (0.02 log units) above it; the range from low to high includes it.
By their numbers in this assay, from the lowest: compounds 4, 3, 2 and 1 (each within the scatter of the next).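

In this assay, among these compounds, the level held by the earlier compounds now reaches one place further out: methyl in place of hydrogen on a saturated chain carbon, ten or more bonds along the chain from a carbonyl carbon, gives a 1.1-fold lower number from compound 3 to compound 4 (0.03 log units; within the scatter) and so opens no gap from the shorter chain. The wider spans read the same way, with ethyl nine bonds along the chain giving a 1.1-fold lower number from compound 2 to compound 4 (0.03 log units; within the scatter) and butyl seven bonds along the chain, the largest replacement among the four compounds, giving a 1.3-fold lower number from compound 1 to compound 4 (0.12 log units; within the scatter) so that even this span does not leave the scatter. All four compounds therefore sit on one level with no ranking among them, and nothing available explains why the chain can change in this way without moving the number.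

Whether a longer chain would stay on this level remains open, and the flat reading may not hold beyond the chain lengths shown. Also open, as far as these compounds go, is what a carboxylic acid or an amine at the far end of the chain, or a phenyl ring there, would do to the number.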